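Replacing 4-methylphenoxy with (1,3-benzothiazol-2-yl)sulfanyl: cytotoxicity notes

The compounds below may be only part of what the source reports. "The series", "measured", "known", "first", "only" and "open" are said of these compounds alone.

Of the compounds shown here, three with a shared core have been read in an ADME assay on HEK293 cells (Homo sapiens) for cytotoxicity; on this read-out higher numbers stand for weaker inhibition and lower numbers for stronger inhibition: compound 1 `COC(=O)c1c(C)cc(OC(=O)c2c(C)cc(O)c(/C=N/NC(=O)COc3ccccc3C)c2O)c(C)c1O`, compound 2 `COC(=O)c1c(C)cc(OC(=O)c2c(C)cc(O)c(/C=N/NC(=O)COc3cccc(C)c3)c2O)c(C)c1O` and compound 3 `COC(=O)c1c(C)cc(OC(=O)c2c(C)cc(O)c(/C=N/NC(=O)COc3ccc(C)cc3)c2O)c(C)c1O`. Compound 1 gives > 100000 nM, a limit of the assay and not a number. Compound 2 gives > 100000 nM, likewise a limit. Compound 3 gives > 100000 nM, also a limit, so its standing is known only as a limit, and the whole set shares it: the limit of > 100000 nM in this assay, at which 3 of the 3 values shown sit.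

Compound 4 `COC(=O)c1c(C)cc(OC(=O)c2c(C)cc(O)c(/C=N/NC(=O)CSc3nc4ccccc4s3)c2O)c(C)c1O` is not yet measured. The change is (1,3-benzothiazol-2-yl)sulfanyl in place of 4-methylphenoxy on a saturated chain carbon bound to a carbonyl carbon; in words, (1,3-benzothiazol-2-yl)sulfanyl in place of 4-methylphenoxy on a saturated chain carbon bound to a carbonyl carbon.

The measured steps are a step that the two limits leave unreadable from compound 1 to compound 2, a step that the two limits leave unreadable from compound 1 to compound 3 and a step that the two limits leave unreadable from compound 2 to compound 3. They only exchange 2-methylphenyl, 3-methylphenyl and 4-methylphenyl for one another, and none has a readable size, so they give no measure for replacing the whole group. The expectation for compound 4 therefore starts from the limit of compound 3, > 100000 nM. The expected at least 1.2-fold lower number from compound 3 to compound 4 (0.09 log units; that floor lies within the scatter) is small, toward stronger inhibition in this assay, and a further limit is quite possible. Compound 4 is estimated at 80000 nM, with an expected range from 25000 nM to 200000 nM.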

Compound 4, half-maximal inhibitory concentration: 70100 nM
The estimate for compound 4 lay 1.1-fold (0.06 log units) above the measured number; the measured number falls inside the stated range.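

In this assay, among these compounds, compound 4 gives 70100 nM, a number and not a limit, so this change on a saturated chain carbon bound to a carbonyl carbon yields the only readable value in the set. The exchanges among the three methylphenyl groups cannot be read, and compounds 1, 2 and 3 all sit at a limit: the limit of > 100000 nM in this assay, at which 3 of the 4 values shown sit.

Replacing each methylphenoxy group with (1,3-benzothiazol-2-yl)sulfanyl gives an at least 1.4-fold lower number from compound 3 to compound 4 (0.15 log units; that floor lies within the scatter), an at least 1.4-fold lower number from compound 2 to compound 4 (0.15 log units; that floor lies within the scatter) and an at least 1.4-fold lower number from compound 1 to compound 4 (0.15 log units; that floor lies within the scatter), so each comparison sets only a floor and none shows a step beyond the scatter.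

The change replaces the oxygen link and the methylphenyl ring together with a sulfur link and a ring system holding a five-membered aromatic ring, and the compounds shown do not separate these two parts. Going by these compounds, a phenylsulfanyl group or a (1,3-benzothiazol-2-yl)oxy group at this place would part them, while the true size of the step stays open as long as compounds 1, 2 and 3 are known only as limits.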